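Benzyl ether of a hydroxymethyl compound: an expectation

The compounds below may be only part of what the source reports. "The series", "measured", "known", "first", "only" and "open" are said of these compounds alone.

Measured compounds, each at the limit of the assay:
Compound 1 `O=c1ccc(CO)nn1Cc1ccccc1` gives > 100000 nM.
Compound 2 `O=c1ccc(CCO)nn1Cc1ccccc1` gives > 100000 nM.
Compound 3 `Cn1nc(CCOCc2ccccc2)ccc1=O` gives > 100000 nM.

In a functional assay on aorta (Rattus norvegicus) (on this read-out lower numbers stand for stronger inhibition and higher numbers for weaker inhibition), compound 1 stands only at a limit, not at a number. Within the data shown here, the one step among measured compounds, a step that the two limits leave unreadable from compound 1 to compound 2, cannot be sized, because both ends sit at the limit (the limit of > 100000 nM in this assay, at which 3 of the 3 values shown sit). Compound 4 `O=c1ccc(COCc2ccccc2)nn1Cc1ccccc1` differs from compound 1 by benzyl in place of hydrogen on an oxygen on a saturated carbon. No measured step bears directly on this change; the only guide is that every compound shown, including compound 3 which carries the same benzyl ether, sits at the limit. The step from compound 1 to compound 4 is therefore expected to be none readable, a step that the limit leaves unreadable from compound 1 to compound 4. Compound 4 is expected at 150000 nM, in a range from 30000 nM to 1000000 nM, most likely reported as a limit again.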

Compound 4, half-maximal inhibitory concentration: 35300 nM
For compound 4 the middle estimate is 4.2-fold (0.63 log units) above the measured one, and the stated range covers the measured number.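

In this assay, among these compounds, putting benzyl on the oxygen gives an at least 2.8-fold lower number from compound 1 to compound 4 (0.45 log units; beyond the scatter), the first step in this set that can be sized. The oxygen on the saturated carbon is therefore a place where a change can lift a compound off the limit, and the true step may be larger than the bound shows. Compound 4 alone carries a real number, while the others remain at a limit: the limit of > 100000 nM in this assay, at which 3 of the 4 values shown sit.

From the compounds shown here alone, it remains open whether methyl or a longer chain such as phenethyl on this oxygen would do the same. Going by these compounds, how an amine or a carboxylic acid on the benzyl ring would read is also open.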